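Swapping the aryl amide of compound 1 for a thiazole

A few compounds are considered here, and "the series" means these few. Any claim that something is new, unique, unknown or untested is made for them only; others in the source may bear on it.

For the measured compounds named here, in a functional assay on HCT-116 cells (Homo sapiens) for inhibition, read by colorimetric assay, with a stated time of 3 days (on this read-out lower numbers stand for stronger inhibition and higher numbers for weaker inhibition), compound 1 `O=C(CCCCCCNC(=O)C(O)(O)C(F)(F)F)Nc1ccc(Br)cc1` gives 3130 nM, the lowest of the two numbers known. Going by the values given here, compound 2 `Cc1ccc(S(=O)(=O)Nc2ccc(NC(=O)CCCCCCNC(=O)C(O)(O)C(F)(F)F)cc2)cc1` gives 17200 nM, and the only measured step, a 5.5-fold higher number from compound 1 to compound 2 (0.74 log units; beyond the scatter), is a change of ((4-methylphenyl)sulfonyl)amino in place of bromo on an aromatic carbon. Compound 3 `O=C(CCCCCCNC(=O)C(O)(O)C(F)(F)F)Nc1nccs1` has not been measured; it differs from compound 1 by 1,3-thiazol-2-yl in place of 4-bromophenyl on an amide-type nitrogen. That step sits on the amide-type nitrogen rather than on the ring, so the step from compound 1 to compound 2 does not bear on it directly; it shows only that this part of the molecule can move the number well beyond the scatter. Compound 3 is therefore expected to land near compound 1 or somewhat weaker, an expected step of a 1.6-fold higher number from compound 1 to compound 3 (0.20 log units; within the scatter), with the estimate for compound 3 at 5000 nM and a range from 1500 nM to 18000 nM.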

Compound 3, half-maximal inhibitory concentration: 10800 nM
The estimate for compound 3 lay 2.2-fold (0.33 log units) below the measured number; the range from low to high includes it.
By their numbers in this assay, from the lowest: compound 1; then compounds 3 and 2 (each within the scatter of the next).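

In this assay, a 3.5-fold higher number from compound 1 to compound 3 (0.54 log units; beyond the scatter), so at this position the whole aryl group, and not only the substituent on it, can move the number beyond the scatter. Exchanging 4-bromophenyl for 1,3-thiazol-2-yl on the amide-type nitrogen gives up part of the inhibition seen with compound 1, and both single changes shown so far raise the number, the other being a 5.5-fold higher number from compound 1 to compound 2 (0.74 log units; beyond the scatter). Nothing at hand accounts for either step.

The compounds shown leave open whether the loss follows from the change of ring itself or from the loss of the bromine, which a bromo-substituted 1,3-thiazol-2-yl or a plain phenyl on the same nitrogen would help to separate. They also leave open how a pyridin-2-yl group would behave there, and whether a longer chain would alter the size of this step.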